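This account rests on a few compounds, and the source may have more. Where it says the series, first, only, none or still open, it means among the compounds named here.

Compound 1 `CCc1ccc(CN(Cc2ccc(F)cc2)Cc2cc3ccc(C)cc3[nH]c2=O)cc1`, compound 2 `Cc1ccc2[nH]c(=O)c(CN(Cc3ccccc3)Cc3ccc(C(C)(C)C)cc3)cc2c1` and compound 3 `Cc1ccc2[nH]c(=O)c(CN(Cc3cccc(F)c3)Cc3ccc4ccccc4c3)cc2c1` share one core and were all tested in a toxicity assay on MDCK cells (Canis lupus familiaris) for cytotoxicity, read by crystal violet staining, with a stated time of 48 h; on this read-out lower numbers stand for higher toxicity in this test and higher numbers for lower toxicity in this test. In this assay compound 1 gives only a limit of the assay, > 33000 nM. Compound 2 likewise reaches no number in this assay and stands at the limit > 5000 nM. Compound 3 also gives only a limit in this assay, > 5000 nM. Where compound 2 stands among the three values shown is therefore a question of limits: it sits at the limit of > 5000 nM in this assay, at which 2 of the 3 values shown sit, while the one remaining value sits at the limit of > 33000 nM in this assay, at which 1 of the 3 values shown sits. No two of these compounds differ in only one place, so no measured step can be drawn between them, and none of the three values is a real number.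

Compound 4 `Cc1ccc2[nH]c(=O)c(CN(Cc3ccc(OCCO)cc3)Cc3ccc(C(C)(C)C)cc3)cc2c1` has not yet been measured. It differs from compound 2 in a single place: 2-hydroxyethoxy in place of hydrogen on an aromatic carbon. Among the measured compounds shown here, nothing among the measured compounds speaks to this group, and all three values are limits. In this assay the expected step is a step that the limit leaves unreadable from compound 2 to compound 4, which amounts to none beyond the scatter. Compound 4 is accordingly expected to give about 20000 nM in this assay, within a range of 5000 nM to 80000 nM, and it would most likely again be reported only as a limit.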

Compound 4, half-maximal cytotoxic concentration: > 5000 nM
Compound 4: a limit, no number; the forecaster's own chance of this, stated with the estimate: 80%; the middle value does not contradict the limit.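

Compound 2 and compound 4 both stop at a limit in this assay, so no step can be read between them. The compounds shown leave open what the half-maximal cytotoxic concentration of any of them actually is, and whether 2-hydroxyethoxy in place of hydrogen on an aromatic carbon changes it at all.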